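Moving a fluorine on the pyridine ring: compound 4

The source may report more compounds than this note shows. Statements on the series, on what has been measured and on what is new or still open speak of the compounds shown alone.

The set under study is three amides with a shared core that carries a triple bond to a fluorinated aromatic ring. Compound 1 `C[C@@H](NC(=O)c1ccc(C#Cc2ccccc2F)cn1)C(C)(C)O` gives 29.6% in an ADME assay on HEK293 cells for agonist activity at metabotropic glutamate receptor 5 (Rattus norvegicus), read by fluorescence and calcium flux; on this read-out higher numbers stand for larger maximal responses and lower numbers for smaller maximal responses. Compound 2 `C[C@@H](NC(=O)c1ccc(C#Cc2ccc(F)cc2)cn1)C(C)(C)O` gives 38.4%, and compound 3 `C[C@@H](NC(=O)c1ccc(C#Cc2ccc(F)cn2)cn1)C(C)(C)O` gives 13.5%. Compound 3 stands lowest of the three: one step is a number 16.1 percentage points lower from compound 1 to compound 3 (beyond the scatter), and the other is a number 24.9 percentage points lower from compound 2 to compound 3 (beyond the scatter), both beyond the usual scatter.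

Compound 4 `C[C@@H](NC(=O)c1ccc(C#Cc2cc(F)ccn2)cn1)C(C)(C)O` keeps the core of compound 3 and has the same atoms joined differently: 4-fluoropyridin-2-yl in place of 5-fluoropyridin-2-yl on a triple-bonded carbon. Going by the values given here, the only measured step that resembles this move of a fluorine around a ring is a number 8.8 percentage points higher from compound 1 to compound 2 (within the scatter), which stayed within the scatter. The two larger steps concern the exchange of a fluorophenyl for a fluoropyridinyl ring, not a shift of the fluorine itself, so they do not speak directly to this change.

For compound 4 the step from compound 3 is therefore expected to be small, a number 3.5 percentage points higher from compound 3 to compound 4 (within the scatter), with no clear direction. Compound 4 is estimated to reach 17% in this assay, within a range from 8% to 30%.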

Compound 4, largest response reached (reported as efficacy), in percent of the reference or control that the assay uses: 33%
Compound 4: middle estimate off by 16 percentage points, on the low side; the whole stated range lies below it.
By their numbers in this assay, from the lowest: compound 3; then compounds 1, 4 and 2 (each within the scatter of the next).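

In this assay, the fluorine's place on the pyridine ring clearly matters: 4-fluoropyridin-2-yl in place of 5-fluoropyridin-2-yl gives a number 19.5 percentage points higher from compound 3 to compound 4 (beyond the scatter), whereas the one earlier fluorine shift, on the phenyl ring, was a number 8.8 percentage points higher from compound 1 to compound 2 (within the scatter). The new compound also shows that a pyridine ring on the triple-bonded carbon does not always go with a low number, since the exchange of a fluorophenyl ring gives a number 5.4 percentage points lower from compound 2 to compound 4 (within the scatter) and a number 3.4 percentage points higher from compound 1 to compound 4 (within the scatter), so among these compounds the low response belongs to the 5-fluoropyridin-2-yl group of compound 3, not to fluoropyridinyl rings in general. Nothing available here explains why the two fluoropyridinyl groups differ.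

The compounds shown leave open what the fluorine itself contributes, a question that a plain pyridin-2-yl group on the same carbon would address. They also leave open whether another group at the same place on the ring, such as in 4-chloropyridin-2-yl or 4-methoxypyridin-2-yl, would keep the response in the range of compound 4.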